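Replacing 2-phenoxyethyl with 2-phenylethenyl on a carbonyl carbon

The compounds below may be only part of what the source reports. "The series", "measured", "known", "first", "only" and "open" are said of these compounds alone.

Compound 1 `CCCCC(=O)OCCc1c(-c2ccccc2Cl)c2cc(Cl)ccc2[nH]c1=O` gives 200000 nM
Compound 2 `O=C(CCOc1ccccc1)OCCc1c(-c2ccccc2Cl)c2cc(Cl)ccc2[nH]c1=O` gives 46000 nM

In an ADME assay on HepG2 2.2.15 cells (Homo sapiens) for cytotoxicity (a lower number here means that less compound is tolerated, a higher number that more compound is tolerated), compound 2 holds the lower of the two numbers, at 46000 nM, while compound 1 stands at 200000 nM. Within the data shown here, the only measured step, a 4.3-fold lower number from compound 1 to compound 2 (0.64 log units; beyond the scatter), placed phenoxy where ethyl had been on a saturated chain carbon.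

Compound 3 `O=C(/C=C/c1ccccc1)OCCc1c(-c2ccccc2Cl)c2cc(Cl)ccc2[nH]c1=O` departs from compound 2 by 2-phenylethenyl in place of 2-phenoxyethyl on a carbonyl carbon, with 2-phenylethenyl in place of 2-phenoxyethyl on a carbonyl carbon. Both groups carry one six-membered aromatic ring of carbon only, whereas the group in compound 1 does not. Among the measured compounds shown here, no measured step makes this exact change, so a 4.3-fold lower number from compound 1 to compound 2 (0.64 log units; beyond the scatter) bears on it only loosely, as the sole indication of how far a change in this part of the molecule has moved the number. A small step is therefore expected in this assay, perhaps none beyond the scatter, with a slight lean towards a higher number. The expected step is a 1.3-fold higher number from compound 2 to compound 3 (0.12 log units; within the scatter). The estimate for compound 3 is 60000 nM, with an expected range from 22000 nM to 170000 nM.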

Compound 3, half-maximal cytotoxic concentration: 230000 nM
The estimate for compound 3 lay 3.8-fold (0.58 log units) below the measured number, and the stated range ends below it.
By their numbers in this assay, from the lowest: compound 2; then compounds 1 and 3 (each within the scatter of the next).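

On the carbonyl carbon, exchanging 2-phenoxyethyl for 2-phenylethenyl moves the reading in this assay substantially, with a 5.0-fold higher number from compound 2 to compound 3 (0.70 log units; beyond the scatter), even though the two groups carry the same kind of six-membered aromatic ring of carbon only. The ring alone therefore does not go with the lower number, since compound 2 and compound 3 both have it and only compound 2 holds that lower number. Exchanging butyl for 2-phenylethenyl on the same carbon makes no difference that can be told from the scatter, with a 1.2-fold higher number from compound 1 to compound 3 (0.06 log units; within the scatter), so among these three esters, compound 2 alone stands apart.

The change from compound 2 to compound 3 removes the oxygen of 2-phenoxyethyl and brings in a double bond at the same time, so the compounds shown leave open which of the two goes with the shift, and a 2-phenylethyl group on this carbonyl carbon, with neither feature, would separate them. Nothing measured here accounts for why the numbers fall as they do.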